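Aryl imidazoline series: thiazole in place of pyrazine

A few compounds are considered here, and "the series" means these few. Any claim that something is new, unique, unknown or untested is made for them only; others in the source may bear on it.

Measured so far:
compound 1 `Cc1ccnc(-c2ccccc2OCC2=NCCN2)c1` — < 100000 nM
compound 2 `c1ccc(-c2cnccn2)c(OCC2=NCCN2)c1` — 2.51 nM

Within the data shown here, in a functional assay for activation of Alpha-1A adrenergic receptor (Homo sapiens), read by calcium flux (on this read-out lower numbers stand for an effect already at smaller amounts and higher numbers for an effect only at larger amounts of compound), compound 2 gives 2.51 nM, which is the only number among the values shown. For compound 1 the result in this assay is a limit of the assay and not a number, < 100000 nM; this is the limit of < 100000 nM in this assay, at which 1 of the 2 values shown sits.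

Compound 3 `c1ccc(-c2nccs2)c(OCC2=NCCN2)c1` has not yet been measured in this assay. It differs from compound 2 in one place: 1,3-thiazol-2-yl in place of pyrazin-2-yl on an aromatic carbon. No step between two measured compounds is shown, so nothing measured sets the size of this change; the expectation rests on the structural change alone. A small to moderate loss in this assay is expected, with the possibility that the step stays within the usual scatter.

Compound 3 is expected to give 10 nM in this assay, within a range of 1.5 nM to 80 nM.

The estimated step of a 4.0-fold higher number from compound 2 to compound 3 (0.60 log units; beyond the scatter) is what this expectation means.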

Compound 3, half-maximal effective concentration: 2.51 nM
Estimate against measurement, compound 3: 4.0-fold (0.60 log units) above, within the range that was stated.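

In this assay, 1,3-thiazol-2-yl in place of pyrazin-2-yl on an aromatic carbon gives no change at the digits printed from compound 2 to compound 3 (within the scatter). Among these compounds, this is the only readable step at this position, and it shows that, for this pair, a five-membered aromatic ring containing sulfur can stand in place of a six-membered aromatic ring containing two nitrogens without a change beyond the scatter. No measured property among the data shown accounts for this outcome.

Compound 1 gives < 100000 nM in this assay, which is a limit of the assay and not a number, and steps to it cannot be read. From the compounds shown here alone, it remains open whether the same read-out holds with an aminomethyl group, a carboxylic acid or a longer alkyl chain at this position on the shared core.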